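Ethyl to Cyclopentyl on the Urea of Compound 2

The compounds below may be only part of what the source reports. "The series", "measured", "known", "first", "only" and "open" are said of these compounds alone.

Compound 1, `CC(C)c1ccccc1OS(=O)(=O)c1ccc(NC(=O)CCCCl)cc1`: 6200 nM
Compound 2, `CCNC(=O)Nc1ccc(S(=O)(=O)Oc2ccccc2C(C)C)cc1`: 1100 nM

Among the compounds with values here, in a functional assay on HT-29 cells (Homo sapiens) for antiproliferative activity, read by sulforhodamine B assay, with a stated time of 48 h (a lower number here means a stronger inhibitor, a higher number a weaker inhibitor), compound 2 gives the lower of the two numbers and so is the stronger inhibitor of the pair; the single measured step, a 5.6-fold lower number from compound 1 to compound 2 (0.75 log units; beyond the scatter), lies beyond the scatter. Compound 3, `CC(C)c1ccccc1OS(=O)(=O)c1ccc(NC(=O)NC2CCCC2)cc1`, differs from compound 2 by cyclopentyl in place of ethyl on an amide-type nitrogen. Within the data shown here, no measured step touches this position, and the step of a 5.6-fold lower number from compound 1 to compound 2 (0.75 log units; beyond the scatter) concerns the other side of the urea, so it offers no direct guide. A change not beyond the scatter is therefore expected, a 1.4-fold lower number from compound 2 to compound 3 (0.14 log units; within the scatter). Compound 3 is estimated at 800 nM, within 250 nM to 2500 nM.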

Compound 3, half-maximal inhibitory concentration: 7400 nM
Compound 3: middle estimate off by 9.3-fold (0.97 log units), on the low side; the whole stated range lies below it.
By their numbers in this assay, from the lowest: compound 2; then compounds 1 and 3 (each within the scatter of the next).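

In this assay, within the data shown here, cyclopentyl in place of ethyl on the amide-type nitrogen brings a 6.7-fold higher number from compound 2 to compound 3 (0.83 log units; beyond the scatter), so this position, untouched by the earlier steps, responds clearly to the group it carries. The urea alone does not secure the activity of compound 2: cyclopentylamino in place of 3-chloropropyl on the carbonyl carbon gives only a 1.2-fold higher number from compound 1 to compound 3 (0.08 log units; within the scatter). The compounds shown leave open whether the ring or the added carbons matter, as they include no cyclopropyl, no propyl chain and no open-chain pentyl here. No measured evidence available here explains the change at this position.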